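Replacing methoxy with methanesulfonamido in compound 1

The compounds below may be only part of what the source reports. "The series", "measured", "known", "first", "only" and "open" are said of these compounds alone.

Compound 1 `COc1ccc(CNc2c(-c3ccccc3OC)nc3ccccn23)cc1` gives 230 nM
Compound 2 `COc1ccc(CNc2c(-c3cc(Cl)cc(Cl)c3O)nc3ccccn23)cc1` gives 4160 nM

Among the compounds with values here, in a functional assay on HeLa cells (Homo sapiens) for cytotoxicity, read by sulforhodamine B assay, with a stated time of 3 days (a lower number here means a stronger inhibitor, a higher number a weaker inhibitor), compound 1 stands at 230 nM and holds the lower of the two numbers so far, with compound 2 as its only neighbour. The compound still to be measured is compound 3 `COc1ccc(CNc2c(-c3ccccc3NS(C)(=O)=O)nc3ccccn23)cc1` which carries methanesulfonamido in place of methoxy on an aromatic carbon, ortho to a large group (methanesulfonamido in place of methoxy on an aromatic carbon). Within the data shown here, only one measured step bears on this change, and only loosely. That step is an 18-fold higher number from compound 1 to compound 2 (1.26 log units; beyond the scatter) and it is large, well beyond the usual scatter. Among the measured compounds shown here, it alters the same methoxy-bearing aromatic group, but through different substituents, and no measured compound carries methanesulfonamido. Given this single upward step to compound 2 (an 18-fold higher number from compound 1 to compound 2 (1.26 log units; beyond the scatter)), a move towards a higher number is expected in this assay though probably a smaller one, and the uncertainty is wide. The expected step is a 3.5-fold higher number from compound 1 to compound 3 (0.54 log units; beyond the scatter) and it remains an estimate. Compound 3 is thus estimated at 800 nM (expected range 200 nM to 3500 nM).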

Compound 3, half-maximal inhibitory concentration: > 10000 nM
Compound 3 gave a limit, no number (the forecaster's own chance of this, stated with the estimate: 5%); middle value at least 12-fold (1.09 log units) away from the limit.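

Compound 3 stands at a limit of the assay, not at a number: the limit of > 10000 nM in this assay, at which 1 of the 3 values shown sits. In this assay, exchanging methoxy alone for methanesulfonamido, on an aromatic carbon ortho to a large group, gives an at least 43-fold higher number from compound 1 to compound 3 (1.63 log units; beyond the scatter), so this one place on its own can decide whether the compound retains a measurable value in the assay. The earlier step, an 18-fold higher number from compound 1 to compound 2 (1.26 log units; beyond the scatter), had already shown that this aromatic group matters, but it swapped in a differently substituted group and so could not tie the rise to the methoxy place itself.

The compounds shown leave open whether the rise follows the loss of methoxy or the entry of methanesulfonamido, and an amine or an acetamido group at the same place would help to separate the two. They also leave open how far the rise extends past the limit. From the compounds shown here alone, whether a smaller group such as ethoxy would keep the value of compound 1 of 230 nM is likewise open.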